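Amide variation on the stilbene cinnamamide series

A few compounds are considered here, and "the series" means these few. Any claim that something is new, unique, unknown or untested is made for them only; others in the source may bear on it.

Three compounds in this set differ only in the amine attached to the carbonyl. Compound 1 `CCCCN(CCCC)C(=O)/C=C/c1c(/C=C/c2ccc(OC)cc2)cc(OC)cc1OC` gives 6160 nM in a functional assay on A549 cells (Homo sapiens) for inhibition, read by MTT assay, with a stated time of 48 h (on this read-out higher numbers stand for weaker inhibition and lower numbers for stronger inhibition), compound 2 `COc1ccc(/C=C/c2cc(OC)cc(OC)c2/C=C/C(=O)N2CCC(c3ccccc3)CC2)cc1` gives 6690 nM, and compound 3 `COc1ccc(/C=C/c2cc(OC)cc(OC)c2/C=C/C(=O)N2CCC(Cl)CC2)cc1` gives 2080 nM. Compound 3 has the lowest number of the three: a 3.0-fold lower number from compound 1 to compound 3 (0.47 log units; beyond the scatter) and a 3.2-fold lower number from compound 2 to compound 3 (0.51 log units; beyond the scatter), both beyond the scatter, while a 1.1-fold higher number from compound 1 to compound 2 (0.04 log units; within the scatter) is within it. Compound 4 `COc1ccc(/C=C/c2cc(OC)cc(OC)c2/C=C/C(=O)N2CCCC(C)C2)cc1` carries 3-methylpiperidin-1-yl in place of 4-chloropiperidin-1-yl on a carbonyl carbon. For the measured compounds named here, no measured step covers a methyl on the ring or a move of the substituent to another ring carbon; the steps to compound 3 only show that exchanging one amine for another shifts the number by modest amounts in this set. The expectation is therefore a modest step back toward the numbers of compound 1 and compound 2, not a large one, given as a 1.9-fold higher number from compound 3 to compound 4 (0.28 log units; within the scatter). Compound 4 is expected to give about 4000 nM, with a range from 1500 nM to 10000 nM.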

Compound 4, half-maximal inhibitory concentration: 5820 nM
For compound 4 the middle estimate is 1.5-fold (0.16 log units) below the measured one; the measured number falls inside the stated range.
By their numbers in this assay, from the lowest: compound 3; then compounds 4, 1 and 2 (each within the scatter of the next).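

In this assay the exchange of 4-chloropiperidin-1-yl for 3-methylpiperidin-1-yl on the carbonyl carbon gives a 2.8-fold higher number from compound 3 to compound 4 (0.45 log units; beyond the scatter) and so shows that a second piperidine amide does not share the low number of compound 3. With a 1.1-fold lower number from compound 2 to compound 4 (0.06 log units; within the scatter) and a 1.1-fold lower number from compound 1 to compound 4 (0.02 log units; within the scatter) as the other two steps, 3-methylpiperidin-1-yl, 4-phenylpiperidin-1-yl and dibutylamino cannot be told apart, and among these four amines only 4-chloropiperidin-1-yl stands apart. Nothing measured here accounts for that separation.

The step from compound 3 to compound 4 changes both the substituent and the ring carbon that carries it, so the two changes cannot be separated. Open, on these data alone, is whether 4-methylpiperidin-1-yl, 3-chloropiperidin-1-yl or unsubstituted piperidin-1-yl would stay with compound 3 or with the other three.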